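A few compounds are considered here, and "the series" means these few. Any claim that something is new, unique, unknown or untested is made for them only; others in the source may bear on it.

Measured so far in an ADME assay on Caco-2 cells (Homo sapiens) for permeability, in the apical to basolateral direction, at pH 7.4; a lower number here means that the compound crosses the layer more slowly, a higher number that the compound crosses the layer faster:
- compound 1 `Cc1ccc2[nH]c(C(=O)N[C@H]3CN(S(=O)(=O)c4ccccc4)C[C@@H]3C(=O)N[C@@H]3CCCN(C)C3)cc2c1`: 0.76 10^-6 cm/s
- compound 2 `Cc1ccc2[nH]c(C(=O)N[C@H]3CN(S(=O)(=O)c4ccccc4)C[C@@H]3C(=O)N[C@@H]3CCCNC3)cc2c1`: 0.04 10^-6 cm/s
- compound 3 `Cc1ccc2[nH]c(C(=O)N[C@H]3CCN(S(=O)(=O)c4ccccc4Cl)C[C@@H]3C(=O)N[C@H]3CCCN(C)C3)cc2c1`: 0.27 10^-6 cm/s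

Compound 1 and compound 2 differ only by hydrogen in place of methyl on an amine nitrogen in a ring, and this change gave a 19-fold lower number from compound 1 to compound 2 (1.28 log units; beyond the scatter). Compound 3 carries a different core; the difference between the two cores is not broken down here. Compound 4 `Cc1ccc2[nH]c(C(=O)N[C@H]3CCN(S(=O)(=O)c4ccccc4Cl)C[C@@H]3C(=O)N[C@H]3CCCNC3)cc2c1`, not yet measured, stands to compound 3 as compound 2 stands to compound 1, namely by hydrogen in place of methyl on an amine nitrogen in a ring, the same change at the same place. Within the data shown here, since compound 3 already sits at 0.27 10^-6 cm/s, the expectation for compound 4 in this assay is a step of about a 14-fold lower number from compound 3 to compound 4 (1.13 log units; beyond the scatter), resting on the single earlier step from compound 1 to compound 2 and nothing more. Compound 4 is therefore estimated at 0.02 10^-6 cm/s, with a range from 0.005 10^-6 cm/s to 0.08 10^-6 cm/s, and a reported limit rather than a number would not be surprising.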

Compound 4, apparent permeability: < 0.01 10^-6 cm/s
Compound 4: only a limit was reported (the forecaster's own chance of this, stated with the estimate: 35%); middle value at least 2.0-fold (0.30 log units) from the limit.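

In this assay, hydrogen in place of methyl on the amine nitrogen in the ring moved the number the same way on the second core, giving an at least 27-fold lower number from compound 3 to compound 4 (1.43 log units; beyond the scatter). Compound 4 gives < 0.01 10^-6 cm/s, which is a limit of the assay and not a number. The direction of the change therefore holds on both cores, but no difference in its size between them can be claimed, and two pairs make no general rule: the same change on two cores in this assay, a 19-fold lower number (1.28 log units; beyond the scatter) from compound 1 to compound 2 and an at least 27-fold lower number (1.43 log units; beyond the scatter) from compound 3 to compound 4; the limit leaves it open whether they differ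

The compounds shown leave open what an ethyl or acetyl group on that same nitrogen would give in this assay. They also leave open whether the change carries over to cores bearing an amine or a carboxylic acid elsewhere.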